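Notes on the 2,2-difluoroethoxy to methoxy step

A few compounds are considered here, and "the series" means these few. Any claim that something is new, unique, unknown or untested is made for them only; others in the source may bear on it.

Compound 3 `CN1Cc2cc(ccc2S(=O)(=O)C2CC2)NC(=O)CCc2cc(ccc2OCC(F)F)[C@@H](Nc2ccc3c(N)ncc(F)c3c2)C1=O` gives 1.07 h in an ADME assay on liver (Rattus norvegicus) for metabolic stability, using microsomes (a lower number here means that the compound disappears faster, a higher number that the compound lasts longer), the highest of the three numbers, though compound 1 `CN1Cc2cc(ccc2S(=O)(=O)C2CC2)NC(=O)CCc2cccc(c2)[C@@H](Nc2ccc3c(N)ncc(F)c3c2)C1=O` with 0.55 h in this assay lies within the scatter of it; compound 2 `CN1CCc2cccc(c2)[C@@H](Nc2ccc3c(N)ncc(F)c3c2)C(=O)N(C)Cc2cc(ccc2S(=O)(=O)C2CC2)NC1=O` with 0.1 h in this assay lies beyond it. Compound 4 `COc1ccc2cc1CCC(=O)Nc1ccc(S(=O)(=O)C3CC3)c(c1)CN(C)C(=O)[C@@H]2Nc1ccc2c(N)ncc(F)c2c1` differs from compound 3 in one place: hydrogen in place of difluoromethyl on a saturated chain carbon bound to an oxygen on an aromatic ring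

Going by the values given here, the only measured step at this place is a 1.9-fold higher number from compound 1 to compound 3 (0.29 log units; within the scatter), within the scatter. Among the compounds with values here, no measured pair shows difluoromethyl replaced by hydrogen, and compound 2 does not bear on this place. With the oxygen on the aromatic ring kept, a step of no more than the scatter is expected, as a 1.4-fold lower number from compound 3 to compound 4 (0.15 log units; within the scatter). Compound 4 is therefore estimated at 0.75 h, between 0.35 h and 1.6 h.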

Compound 4, half-life: 0.267 h
Compound 4: the middle estimate sits 2.8-fold (0.45 log units) above what was measured, and the stated range ends above it.
By their numbers in this assay, from the lowest: compound 2; then compound 4; then compounds 1 and 3 (each within the scatter of the next).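

In this assay, the difluoromethyl matters at this place: a 4.0-fold lower number from compound 3 to compound 4 (0.60 log units; beyond the scatter) lies beyond the scatter, which the earlier step at this place did not. Methoxy in place of hydrogen gives a 2.1-fold lower number from compound 1 to compound 4 (0.31 log units; beyond the scatter), also beyond the scatter, whereas 2,2-difluoroethoxy in place of hydrogen stayed within it, so keeping the oxygen on the aromatic ring does not by itself keep the number. Nothing available explains this difference.

Still open, as far as these compounds go, is whether ethoxy, 2,2,2-trifluoroethoxy or a longer chain on that oxygen would sit with compound 3 or with compound 4.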